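Methyl on a Chain: Saturated versus Triple-Bonded Carbon

A few compounds are considered here, and "the series" means these few. Any claim that something is new, unique, unknown or untested is made for them only; others in the source may bear on it.

Measured compounds:
compound 1, `COc1cc(Cc2nc3c(N)ncnc3n2CCCCCO)cc(OC)c1OC`: 84900000 nM
compound 2, `COc1cc(Cc2nc3c(N)ncnc3n2CC(C)CCCO)cc(OC)c1OC`: 8770000 nM
compound 3, `C#CCCn1c(Cc2cc(OC)c(OC)c(OC)c2)nc2c(N)nc(F)nc21`: 286000000 nM

All three were tested in a functional assay on MCF7 cells (Homo sapiens) for cytotoxicity; on this read-out lower numbers stand for an effect already at smaller amounts and higher numbers for an effect only at larger amounts of compound. Compound 1 and compound 2 differ in one place, (methyl in place of hydrogen on a saturated chain carbon bound to two saturated chain carbons), and this change gave a 9.7-fold lower number from compound 1 to compound 2 (0.99 log units; beyond the scatter). Compound 3 stands highest of the three; its value lies beyond the scatter from both compound 1 and compound 2, and the difference between its core and the core of compound 1 is not broken down here.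

Compound 4, `CC#CCCn1c(Cc2cc(OC)c(OC)c(OC)c2)nc2c(N)nc(F)nc21`, is not yet measured. It differs from compound 3 by methyl in place of hydrogen on a triple-bonded carbon. Among the compounds with values here, this is the same kind of change as the one from compound 1 to compound 2, but the place is not the same: there the methyl entered on a saturated chain carbon bound to two saturated chain carbons, here it enters on a triple-bonded carbon whose other neighbour is a triple-bonded carbon. Because only a 9.7-fold lower number from compound 1 to compound 2 (0.99 log units; beyond the scatter) is known, and at a different place, a smaller step is expected here, a 3.2-fold lower number from compound 3 to compound 4 (0.50 log units; beyond the scatter). Compound 4 is therefore estimated at 90000000 nM, with a range from 20000000 nM to 300000000 nM.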

Compound 4, half-maximal effective concentration: 95500000 nM
Estimate against measurement, compound 4: 1.1-fold (0.03 log units) below; the range from low to high includes it.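

In this assay, methyl in place of hydrogen on the triple-bonded carbon gave a 3.0-fold lower number from compound 3 to compound 4 (0.48 log units; beyond the scatter), so the number fell with this change, as it had with the methyl on the saturated chain carbon. The direction of the change carried over from one core to the other, but its size did not: the same change on two cores in this assay, a 9.7-fold lower number (0.99 log units; beyond the scatter) from compound 1 to compound 2 and a 3.0-fold lower number (0.48 log units; beyond the scatter) from compound 3 to compound 4, 3.2-fold (0.51 log units) apart, beyond the scatter of two such steps. These two pairs differ both in the core and in the kind of carbon that takes the methyl, so they cannot show which of the two accounts for the gap, and they give no rule for other cores in the series.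

The compounds shown leave open what the same methyl would do at a single place on both cores, for instance with a pent-3-yn-1-yl chain on the core of compound 1. They also leave open how a longer chain on the triple-bonded carbon, or an amine in place of the hydroxyl on the chain of compound 1, would move the number.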